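A few compounds are considered here, and "the series" means these few. Any claim that something is new, unique, unknown or untested is made for them only; others in the source may bear on it.

Of the compounds shown here, three built on one shared core have been measured in a functional assay on L1210 cells (Mus musculus) for cytotoxicity, read by MTT assay, with a stated time of 72 h; a lower number here means a stronger inhibitor, a higher number a weaker inhibitor. Compound 1 `COc1cc(C2=NN(C(C)=O)C(c3ccc([N+](=O)[O-])cc3)C2)cc(OC)c1OC` gives 42000 nM. Compound 3 `COc1ccc(C2CC(c3cc(OC)c(OC)c(OC)c3)=NN2C(C)=O)cc1[N+](=O)[O-]` gives 52000 nM. Compound 2 `COc1ccc(OC)c(C2CC(c3cc(OC)c(OC)c(OC)c3)=NN2C(C)=O)c1` returns only a limit of the assay, > 100000 nM, so for compound 2 a bound is known rather than a number. That bound is the limit of > 100000 nM in this assay, at which 1 of the 3 values shown sits. Going by the values given here, the single one-place step among the measured compounds, an at least 2.3-fold higher number from compound 1 to compound 2 (0.37 log units; beyond the scatter), shows that changing the group on the saturated ring carbon can weaken the compound markedly.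

Compound 4 `COc1cccc(C2CC(c3cc(OC)c(OC)c(OC)c3)=NN2C(C)=O)c1` has not yet been measured. It differs from compound 2 by hydrogen in place of methoxy on an aromatic carbon. Among the compounds with values here, no measured step removes a methoxy from such a position, so the only guide is that compound 2 sits at a limit while compounds 1 and 3, carrying other groups on that carbon, give numbers. Since compound 2 stands at a bound, the step to compound 4 can only read as a lower number or as no change. The step from compound 2 to compound 4 is expected to be an at least 1.1-fold lower number from compound 2 to compound 4 (0.04 log units; that floor lies within the scatter), a small movement within the scatter, with a real chance that compound 4 also returns only a limit. Compound 4 is therefore expected to give 90000 nM, with a range from 40000 nM to 200000 nM in this assay.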

Compound 4, half-maximal inhibitory concentration: 44000 nM
Estimate against measurement, compound 4: 2.0-fold (0.31 log units) above; low and high end bracket the measured number.
By their numbers in this assay, from the lowest: compounds 1, 4 and 3 (each within the scatter of the next). At a limit, above all of these: compound 2.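

In this assay, taking a single methoxy off the 2,5-dimethoxyphenyl group to leave 3-methoxyphenyl gives an at least 2.2-fold lower number from compound 2 to compound 4 (0.35 log units; beyond the scatter), so this one aromatic carbon, ortho to a large group and para to a methoxy group, is enough to bring the series back from the limit to a measurable number. Compound 2 gives > 100000 nM, which is a limit of the assay and not a number: the limit of > 100000 nM in this assay, at which 1 of the 4 values shown sits. The new compound also reads level with the nitro compound, at a 1.0-fold higher number from compound 1 to compound 4 (0.02 log units; within the scatter), which shows that a methoxy on this ring does not by itself go with a weak reading: among the compounds shown, only the 2,5-dimethoxyphenyl group of compound 2 does.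

From the compounds shown here alone, the true size of the step away from compound 2 stays open, as its end point is only a bound. Also open, going by these compounds, is how a hydroxyl group, an amine or a fluorine on that same aromatic carbon would read, and whether a plain phenyl ring with no methoxy at all would stay level with compound 4.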